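The source may hold more compounds than are shown below. What is called first, only, known or untested is meant among the compounds shown, and "the series" means these compounds.

Measured in a functional assay on K562 cells (Homo sapiens) for cytotoxicity, read by MTT assay, with a stated time of 48 h (a lower number here means a stronger inhibitor, a higher number a weaker inhibitor), so far:
Compound 1 `Cc1ccc(CN2CCN(C(=O)CN[C@H]3CCN(S(=O)(=O)Cc4ccccc4)C3)CC2)cc1`: 8200 nM
Compound 2 `O=C(CN[C@H]1CCN(S(=O)(=O)Cc2ccccc2)C1)N1CCN(Cc2ccc(Cl)cc2)CC1`: 9200 nM
Compound 3 `O=C(CN[C@H]1CCN(S(=O)(=O)Cc2ccccc2)C1)N1CCN(Cc2ccc(F)cc2)CC1`: 14300 nM

Compound 3 at 14300 nM stands within the scatter of both other compounds. Compound 4 `COc1cccc(CN2CCN(C(=O)CN[C@H]3CCN(S(=O)(=O)Cc4ccccc4)C3)CC2)c1` differs from it in one group: 3-methoxyphenyl in place of 4-fluorophenyl on a saturated chain carbon bound to an amine nitrogen in a ring is the whole change. Among the compounds with values here, the steps that bear on this are swaps on the aromatic ring: a 1.7-fold higher number from compound 1 to compound 3 (0.24 log units; within the scatter) and a 1.6-fold higher number from compound 2 to compound 3 (0.19 log units; within the scatter) and also a 1.1-fold higher number from compound 1 to compound 2 (0.05 log units; within the scatter) all stay within the scatter. Within the data shown here, no measured compound carries the 3-methoxyphenyl group, so the data suggest no direction. No step beyond the scatter is expected, and the estimated step is a 1.3-fold lower number from compound 3 to compound 4 (0.11 log units; within the scatter) and no more. Compound 4 is estimated at 11000 nM in this assay with an expected range of 5000 nM to 25000 nM as its span.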

Compound 4, half-maximal inhibitory concentration: 60800 nM
For compound 4 the middle estimate is 5.5-fold (0.74 log units) below the measured one; measured number outside the range, above it.
By their numbers in this assay, from the lowest: compounds 1, 2 and 3 (each within the scatter of the next); then compound 4.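

The three swaps among 4-methylphenyl, 4-chlorophenyl and 4-fluorophenyl had all stayed within the scatter, but 3-methoxyphenyl gives a 4.3-fold higher number from compound 3 to compound 4 (0.63 log units; beyond the scatter) and a 6.6-fold higher number from compound 2 to compound 4 (0.82 log units; beyond the scatter) and a 7.4-fold higher number from compound 1 to compound 4 (0.87 log units; beyond the scatter) in this assay. This position therefore does respond to the group it carries, and here all three steps run towards a weaker inhibitor. Nothing available accounts for this change.

The change alters both the substituent and its place on the ring, and the compounds shown do not separate the two. A 4-methoxyphenyl or 3-fluorophenyl group at this position would tell them apart.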